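The source may report more compounds than this note shows. Statements on the series, on what has been measured and on what is new or still open speak of the compounds shown alone.

Measured so far in a functional assay on PC-3 cells (Homo sapiens) for inhibition, read by MTT assay, with a stated time of 48 h; a lower number here means a stronger inhibitor, a higher number a weaker inhibitor:
- compound 1 `C=C1CC[C@@H]2[C@](C)(CO)[C@H](O)CC[C@@]2(C)[C@@H]1CC(Sc1ccc(F)cc1)C1=CCOC1=O`: 16000 nM
- compound 2 `C=C1CC[C@@H]2[C@](C)(CO)[C@H](O)CC[C@@]2(C)[C@@H]1CC(Sc1nccs1)C1=CCOC1=O`: 14000 nM
- compound 3 `C=C1CC[C@@H]2[C@](C)(CO)[C@H](O)CC[C@@]2(C)[C@@H]1C/C=C1/C(=O)OC[C@H]1OC(=O)CSc1ccc(C)cc1`: 27000 nM

Compound 3 sits with compounds 1 and 2; its gaps to both lie within the scatter, so no ordering among the three is secure. Compound 4 `C=C1CC[C@@H]2[C@](C)(CO)[C@H](O)CC[C@@]2(C)[C@@H]1C/C=C1/C(=O)OC[C@H]1OC(=O)CCCSc1ccccn1` differs from compound 3 by 2-((pyridin-2-yl)sulfanyl)ethyl in place of (4-methylphenyl)sulfanyl on a saturated chain carbon bound to a carbonyl carbon. Going by the values given here, the only measured single step, a 1.1-fold lower number from compound 1 to compound 2 (0.06 log units; within the scatter), exchanges an aryl group on a sulfur elsewhere in the molecule and was itself within the scatter; it is the nearest comparison, yet does not touch the ester side chain changed here. Nothing measured therefore argues for a step beyond the scatter in this assay. The estimated step is a 1.2-fold lower number from compound 3 to compound 4 (0.09 log units; within the scatter). For compound 4 the expected value is 22000 nM, within 8000 nM to 60000 nM.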

Compound 4, half-maximal inhibitory concentration: 14000 nM
Beside the measured number, compound 4's estimate is 1.6-fold (0.20 log units) above it; low and high end bracket the measured number.
By their numbers in this assay, from the lowest: compounds 2, 4, 1 and 3 (each within the scatter of the next).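

On the saturated chain carbon bound to a carbonyl carbon, 2-((pyridin-2-yl)sulfanyl)ethyl in place of (4-methylphenyl)sulfanyl gives a 1.9-fold lower number from compound 3 to compound 4 (0.29 log units; within the scatter) in this assay. Going by these compounds alone, this is the first step read at this position, and a change of both chain and aromatic ring at once still stays within the scatter. The two changes cannot be separated here, and nothing available accounts for the step. On these data alone, whether a pyridin-2-yl group alone or the longer chain alone gives the same reading remains open. So does whether an amine or a carboxylic acid at this position moves the number beyond the scatter.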